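Methyl oxadiazole in place of methyl tetrazole: cytotoxicity outlook

This account rests on a few compounds, and the source may have more. Where it says the series, first, only, none or still open, it means among the compounds named here.

Compound 1 `CCn1nnc(-c2ccc(OCCC(C)CCN3CCN(c4ccncc4)C3=O)cc2)n1` — in an ADME assay on cells (Homo sapiens) for cytotoxicity (on this read-out lower numbers stand for higher toxicity in this test and higher numbers for lower toxicity in this test), compound 1 gives > 12500 nM, a limit.
Compound 2 `CCc1nc(-c2ccc(OCCC(C)CCN3CCN(c4ccncc4)C3=O)cc2)no1` — in this assay compound 2 gives > 25000 nM, a limit.
Compound 3 `CC(CCOc1ccc(-c2nnn(C)n2)cc1)CCN1CCN(c2ccncc2)C1=O` — in this assay compound 3 gives > 25000 nM, a limit.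

Compound 3 stands only at a limit, as does every other value shown; none of the three compounds yields a number. Compound 4 `Cc1nc(-c2ccc(OCCC(C)CCN3CCN(c4ccncc4)C3=O)cc2)no1` differs from compound 3 by 5-methyl-1,2,4-oxadiazol-3-yl in place of 2-methyl-2H-tetrazol-5-yl on an aromatic carbon. The step from compound 2 to compound 3 is the closest comparison: a step that the two limits leave unreadable from compound 2 to compound 3. The other two steps are likewise unreadable, a step that the two limits leave unreadable from compound 1 to compound 2 and a step that the two limits leave unreadable from compound 1 to compound 3, because all values sit at the limits the limit of > 12500 nM in this assay, at which 1 of the 3 values shown sits, and (the limit of > 25000 nM in this assay, at which 2 of the 3 values shown sit). No size or direction can therefore be read for the step in this assay. Compound 4 is expected to remain at the limit, a step that the limit leaves unreadable from compound 3 to compound 4. The estimate for compound 4 is 30000 nM, between 12500 nM and 70000 nM.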

Compound 4, half-maximal cytotoxic concentration: > 6250 nM
Compound 4: a limit, no number (the forecaster's own chance of this, stated with the estimate: 85%); the middle value does not contradict the limit.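

Compound 4 gives > 6250 nM in this assay, a limit, and its steps from compound 1, compound 2 and compound 3 cannot be read. Going by these compounds, whether 5-methyl-1,2,4-oxadiazol-3-yl and 2-methyl-2H-tetrazol-5-yl differ at all in this assay stays open.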